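The source may hold more compounds than are shown below. What is called first, only, known or untested is meant among the compounds shown, and "the series" means these compounds.

Measured so far:
compound 1 `Cc1c(C(N)=O)sc2nc(NN)n(Cc3ccccc3)c(=O)c12` gives 8.36 mg/kg in a functional assay on the whole organism (strain albino) for inhibition, with Rattus norvegicus as the target, read by paw edema, in the formalin test, with a stated time of 1 h; on this read-out lower numbers stand for an effect already at smaller amounts and higher numbers for an effect only at larger amounts of compound
compound 2 `Cc1c(C(N)=O)sc2nc(-n3nc(-c4ccc(Cl)cc4)cc3N)n(Cc3ccccc3)c(=O)c12` gives 9.65 mg/kg in this assay

Going by the values given here, compound 1 holds the lower of the two numbers; the only other measured compound, compound 2, sits so close that the two values fall within the usual scatter, so no order between them can be claimed.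

Compound 3 `CC1=NN(c2nc3sc(C(N)=O)c(C)c3c(=O)n2Cc2ccccc2)C(=O)C1` has not been measured. It differs from compound 1 in one place: a group of 7 heavy atoms (4 carbon, 2 nitrogen, 1 oxygen; one five-membered non-aromatic ring with 2 hetero atoms) in place of a group of 2 heavy atoms (2 nitrogen; no ring), on an aromatic carbon. Among the compounds with values here, no step between two measured compounds that differ in a single place is available, so the size of this change cannot be calibrated from the series itself. The two values in hand, both from compounds with different groups at this same place, lie within scatter of each other, so the expected step is none beyond the scatter, with at most a slight lean toward a higher number.

Compound 3 is expected to give 10 mg/kg, with a range from 5 mg/kg to 20 mg/kg; this corresponds to an estimated step of a 1.2-fold higher number from compound 1 to compound 3 (0.08 log units; within the scatter).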

Compound 3, dose for half-maximal effect: 10.5 mg/kg
Beside the measured number, compound 3's estimate is 1.1-fold (0.02 log units) below it; low and high end bracket the measured number.
By their numbers in this assay, from the lowest: compounds 1, 2 and 3 (each within the scatter of the next).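

The series now holds its first single-place step in this assay: a five-membered non-aromatic ring with 2 hetero atoms in place of the aminoamino group, on the aromatic carbon between two ring nitrogen atoms, gives a 1.3-fold higher number from compound 1 to compound 3 (0.10 log units; within the scatter). A group of 7 heavy atoms with 0 hydrogen-bond donors therefore cannot be told apart in this read-out from a group of 2 heavy atoms with 2 hydrogen-bond donors, so this exchange at this position leaves no effect that can be read. No measurement at hand bears on why the two numbers stand so close.

Going by these compounds, whether a dimethylamino group, a carboxylic acid or a longer alkyl chain on this carbon would stand clear of the scatter remains open. The compounds shown also leave open how the read-out responds to replacing the benzyl group, for example with a methyl group.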